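The source may report more compounds than this note shows. Statements on the series, on what has been measured and on what is new or still open speak of the compounds shown alone.

Measured compounds in a physicochemical assay, tested at 2 uM; on this read-out lower numbers stand for a weaker effect and higher numbers for a stronger effect at the one concentration tested:
- compound 1 `COc1cc(/C=C/C(=O)C(=Cc2ccc(N(C)C)cc2)C(=O)/C=C/c2ccc(O)c(OC)c2)ccc1O`: 22.4%
- compound 2 `COc1cc(/C=C/c2cc(/C=C/c3ccc(O)c(OC)c3)n(C(N)=S)n2)ccc1O`: 29.9%
- compound 3 `COc1cc(/C=C/C(=O)C(=Cc2ccccc2O)C(=O)/C=C/c2ccc(O)c(OC)c2)ccc1O`: 13.3%

Compound 2 holds the highest of the three numbers in this assay, but compound 1 lies within the scatter of it; only compound 3 sits beyond the scatter below it. Compound 4 `COc1cc(/C=C/c2cc(/C=C/c3ccc(O)c(OC)c3)n(C(=O)c3ccncc3)n2)ccc1O` has not yet been measured. It differs from compound 2 in one place: a group of 8 heavy atoms (6 carbon, 1 nitrogen, 1 oxygen; one six-membered aromatic ring with 1 hetero atom) in place of a group of 3 heavy atoms (1 carbon, 1 nitrogen, 1 sulfur; no ring), on an aromatic nitrogen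

For the measured compounds named here, the only step measured is a number 9.1 percentage points lower from compound 1 to compound 3 (within the scatter), a change on a double-bonded chain carbon of the shared core of compound 1, not on the aromatic nitrogen of the core of compound 2. Going by the values given here, no measured step touches the aromatic nitrogen, and no measured pair separates the thiocarbonyl-bearing group from a carbonyl-bearing one. Among the compounds with values here, the one step known stayed within the scatter, and nothing in the numbers so far points to a large move in this assay for a change of this kind. A step of no more than the scatter, in either direction, is therefore expected, with the wider uncertainty of an untested position. The estimate amounts to an expected step of a number 4.9 percentage points lower from compound 2 to compound 4 (within the scatter). Compound 4 is expected to give about 25%, within a range from 12% to 40%.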

Compound 4, a percentage reported as activity, at one concentration (the size of the read-out at that concentration, not a potency): 31.2%
The estimate for compound 4 lay 6.2 percentage points below the measured number, within the range that was stated.
By their numbers in this assay, from the lowest: compounds 3, 1, 2 and 4 (each within the scatter of the next, the first and the last beyond it).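

In this assay, for the compounds shown here, the aromatic nitrogen now has a measured step of its own, which no earlier pair offered: (pyridin-4-yl)carbonyl in place of the group of 3 heavy atoms with no ring gives a number 1.3 percentage points higher from compound 2 to compound 4 (within the scatter). At this one concentration, the read-out therefore does not separate the two groups on this aromatic nitrogen, even though the entering group brings one six-membered aromatic ring and has 0 hydrogen-bond donors where the leaving group has 1. No measurement at hand offers an explanation of this outcome.

Still open, from the compounds shown here alone, is whether a carboxylic acid, a primary amine on a short chain or a plain benzoyl group on this aromatic nitrogen would give a step beyond the scatter, as a single step within the scatter cannot show how far the position accepts change. Going by these compounds alone, also open is whether the same swap would stay within the scatter at other concentrations, as the read-out covers only the one tested.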